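The compounds below may be only part of what the source reports. "The series", "measured", "known", "first", "only" and "open" are said of these compounds alone.

Measured so far:
compound 1, `Cc1ccc(-c2cs/c(=N/NC(=O)CSc3nnnn3C)n2-c2ccccc2)cc1` — compound 1 gives 60.7% in a functional assay on C6 cells (Rattus norvegicus) for cytotoxicity, read by MTT assay, with a stated time of 24 h, tested at 25 ug/mL; a lower number here means a stronger effect, a higher number a weaker effect of the compound at the concentration tested
compound 2, `Cn1nnnc1SCC(=O)N/N=c1/scc(-c2ccc(C#N)cc2)n1-c1ccccc1` — compound 2 gives 43.9% in this assay

Of the two numbers, compound 2 stands lowest; its nearest neighbour is compound 1, and the step of a number 16.8 percentage points lower from compound 1 to compound 2 (beyond the scatter) runs beyond the scatter, with cyano in place of methyl on an aromatic carbon. Compound 3, `Cn1nnnc1SCC(=O)N/N=c1/scc(-c2ccc([N+](=O)[O-])cc2)n1-c1ccccc1`, has not yet been measured in this assay. It differs from compound 2 as follows: nitro in place of cyano on an aromatic carbon. Within the data shown here, no measured step shows this change; the only step at hand, a number 16.8 percentage points lower from compound 1 to compound 2 (beyond the scatter), exchanges a different pair of groups at the same position and so gives no direct guide to the size or direction of the present one. The account therefore treats the step as likely to stay small. The step of a number 3.9 percentage points lower from compound 2 to compound 3 (within the scatter) is the expected outcome. Compound 3 is expected to give about 40% in this assay, with a range from 24% to 58%.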

Compound 3, a percentage reported as activity, at one concentration (the size of the read-out at that concentration, not a potency): 69.3%
Beside the measured number, compound 3's estimate is 29.3 percentage points below it; the whole stated range lies below it.
By their numbers in this assay, from the lowest: compound 2; then compounds 1 and 3 (each within the scatter of the next).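

In this assay, the change from 4-cyanophenyl to 4-nitrophenyl gives a number 25.4 percentage points higher from compound 2 to compound 3 (beyond the scatter), so the read-out at this position depends on which group sits there, and exchanging cyano for nitro is not a neutral swap. Nitro in place of methyl gives a number 8.6 percentage points higher from compound 1 to compound 3 (within the scatter), which means that among these three groups cyano alone stands apart, and the earlier step, a number 16.8 percentage points lower from compound 1 to compound 2 (beyond the scatter), now reads as a feature of cyano and not as the start of a trend running from methyl through the other groups. No measurement at hand bears on why the nitrile separates from the other two groups.

With only three groups at one position, the compounds shown leave open whether any other group at this place, such as an amine, a carboxylic acid, a methoxy group or a chlorine atom, would fall with cyano or with methyl and nitro. They also leave open whether the standing of cyano would hold at other concentrations, since each read-out is a single size at one concentration and not a potency, or with other changes elsewhere on the shared core.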